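The source may report more compounds than this note shows. Statements on the series, on what has been measured and on what is new or still open speak of the compounds shown alone.

Measured in a functional assay for antagonist activity at transient receptor potential cation channel subfamily V member 1 (Homo sapiens), read by FLIPR; a higher number here means a weaker inhibitor, a lower number a stronger inhibitor:
compound 1 `Cc1cccnc1-c1ccc(C(=O)Nc2ccc(C(F)(F)F)cc2)cc1` gives 65 nM.
compound 2 `CCCOc1cccnc1-c1ccc(C(=O)Nc2ccc(C(C)(C)C)cc2)cc1` gives 62 nM.
compound 3 `CCCNc1cccnc1-c1ccc(C(=O)Nc2ccc(C(C)(C)C)cc2)cc1` gives 158 nM.

Compound 3 holds the highest number of the three in this assay; compound 1 and compound 2 sit within the scatter of each other, and each lies beyond the scatter from compound 3. For the measured compounds named here, the one single-point step recorded is a 2.5-fold higher number from compound 2 to compound 3 (0.41 log units; beyond the scatter). Compound 4 `CC(C)(C)c1ccc(NC(=O)c2ccc(-c3ncccc3NS(=O)(=O)c3ccccc3)cc2)cc1` differs from compound 3 by phenylsulfonyl in place of propyl on a nitrogen on an aromatic ring. Going by the values given here, no measured step alters the substituent on that nitrogen: the single recorded step swapped the attaching atom while keeping propyl, so it gives no direct read on a larger group there. The expectation is therefore loosely held, leaning toward a somewhat higher number but with a wide band, an estimated step of a 1.6-fold higher number from compound 3 to compound 4 (0.20 log units; within the scatter). For compound 4 the expected value is 250 nM, estimated range 60 nM to 1000 nM.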

Compound 4, half-maximal inhibitory concentration: 91 nM
The estimate for compound 4 lay 2.7-fold (0.44 log units) above the measured number, and the stated range covers the measured number.
By their numbers in this assay, from the lowest: compounds 2, 1, 4 and 3 (each within the scatter of the next, the first and the last beyond it).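

In this assay, the nitrogen on the aromatic ring accepts phenylsulfonyl in place of propyl, a larger group carrying an aromatic ring, with a step of a 1.7-fold lower number from compound 3 to compound 4 (0.24 log units; within the scatter). Against propoxy on an aromatic carbon, (phenylsulfonyl)amino gives a 1.5-fold higher number from compound 2 to compound 4 (0.17 log units; within the scatter), so the loss beyond the scatter seen with propylamino does not recur with this group. Nothing shown gives a reason for this result. Open, as far as these compounds go, is how methylsulfonyl or acetyl on that nitrogen would read, and whether a chloro or methoxy group on the phenyl ring of phenylsulfonyl would shift the number.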